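Fluorinating the Chain End of a Glutamate Receptor Modulator

This account rests on a few compounds, and the source may have more. Where it says the series, first, only, none or still open, it means among the compounds named here.

Compound 1, `CC(C)CCn1ccc(CCc2ccccc2)c(C#N)c1=O`: 361 nM
Compound 2, `CCCCn1ccc(N2CCC(c3ccccc3)CC2)c(C#N)c1=O`: 95 nM

Both compounds were tested in a functional assay on CHO cells for positive allosteric modulation of metabotropic glutamate receptor 2 (Homo sapiens), with a stated time of 30 min (on this read-out higher numbers stand for an effect only at larger amounts of compound and lower numbers for an effect already at smaller amounts), where compound 1 gives 361 nM and compound 2 gives 95 nM. Compound 2 therefore stands at the lower of the two numbers, and the gap to compound 1 is wider than the usual scatter of such measurements. The two compounds differ in more than one place, so the gap cannot be traced to a single change.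

Compound 3, `N#Cc1c(N2CCC(c3ccccc3)CC2)ccn(CCCC(F)(F)F)c1=O`, is compound 2 with one alteration: trifluoromethyl in place of methyl on a saturated chain carbon, three bonds along the chain from an aromatic nitrogen. Among the compounds with values here, nothing among the measured compounds shows what this particular change does, since no pair here differs only in this way. The expectation for compound 3 thus rests on compound 2 alone, with the change treated as one that need not move the number beyond the scatter in either direction. The step expected from compound 2 to compound 3 in this assay is a 1.1-fold higher number from compound 2 to compound 3 (0.02 log units; within the scatter). For compound 3 the estimated value in this assay is 100 nM, with a range from 40 nM to 250 nM.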

Compound 3, half-maximal effective concentration: 355 nM
Compound 3: the middle estimate sits 3.6-fold (0.55 log units) below what was measured; the measured number lies above the stated range.
By their numbers in this assay, from the lowest: compound 2; then compounds 3 and 1 (each within the scatter of the next).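

Changing butyl to 4,4,4-trifluorobutyl gives a 3.7-fold higher number from compound 2 to compound 3 (0.57 log units; beyond the scatter) in this assay and so means that more compound is needed for the same effect, which shows that this chain end does not tolerate every replacement without a change in the number. This pair differs in one place only, so the size of this single change can be read directly, whereas the gap between compound 1 and compound 2 could not be traced to any one difference. No measurement is available that bears on why the number moves, so the pair gives the size of the step and nothing about its origin.

The compounds shown leave open whether all of the added fluorine is needed for this step, which a chain ending in a single fluorine or in a difluoromethyl group could help to settle, and whether a chain end that is not fluorinated but larger, such as pentyl, would give a similar number. They also leave open whether the same change would have a step of similar size on the chain of compound 1, or whether a chain ending in a hydroxyl group or an amine would fare differently.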